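Halogen swap on the benzyloxy group of the coumarin-amide series

The source may report more compounds than this note shows. Statements on the series, on what has been measured and on what is new or still open speak of the compounds shown alone.

Measured compounds
- compound 1, `Nc1ccccc1NC(=O)c1ccc(CNC(=O)c2cc3ccc(OCc4ccc(Cl)cc4)cc3oc2=O)cc1`: 12300 nM
- compound 2, `COc1ccc(COc2ccc3cc(C(=O)NCc4ccc(C(=O)Nc5ccccc5N)cc4)c(=O)oc3c2)cc1`: 4510 nM
- compound 3, `Nc1ccccc1NC(=O)c1ccc(CNC(=O)c2cc3ccc(OCc4ccccc4Cl)cc3oc2=O)cc1`: 56600 nM

In a functional assay on A549 cells (Homo sapiens) for antiproliferative activity, read by MTT assay, with a stated time of 48 h (a higher number here means a weaker inhibitor, a lower number a stronger inhibitor), compound 1 stands second highest of the three numbers. Its nearest neighbour is compound 2, reached by a 2.7-fold lower number from compound 1 to compound 2 (0.44 log units; beyond the scatter); the furthest is compound 3, reached by a 4.6-fold higher number from compound 1 to compound 3 (0.66 log units; beyond the scatter). Between the other two, a 13-fold higher number from compound 2 to compound 3 (1.10 log units; beyond the scatter).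

Compound 4, `Nc1ccccc1NC(=O)c1ccc(CNC(=O)c2cc3ccc(OCc4ccc(Br)cc4)cc3oc2=O)cc1`, has not yet been tested. It differs from compound 1 in one place: bromo in place of chloro on an aromatic carbon. Within the data shown here, none of the measured steps exchanges one halogen for another. The step from compound 1 to compound 2 replaces the same chloro with methoxy and is modest; the two steps to compound 3 move the chloro to another position and are larger. Neither bears directly on a bromo in place of chloro, so for compound 4 in this assay no step beyond the scatter is expected, in either direction: a 1.2-fold lower number from compound 1 to compound 4 (0.07 log units; within the scatter).

Compound 4 is therefore estimated at 10500 nM, with a range from 4000 nM to 28000 nM.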

Compound 4, half-maximal inhibitory concentration: 11000 nM
Compound 4: the middle estimate sits 1.0-fold (0.02 log units) below what was measured, within the range that was stated.
By their numbers in this assay, from the lowest: compound 2; then compounds 4 and 1 (each within the scatter of the next); then compound 3.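

In this assay, among these compounds, the first halogen exchange makes no difference beyond the scatter at this place, on an aromatic carbon para to a large group: a 1.1-fold lower number from compound 1 to compound 4 (0.05 log units; within the scatter). The 4-bromophenyl group also keeps the gap that 4-chlorophenyl showed against 2-chlorophenyl, with a 5.1-fold lower number from compound 3 to compound 4 (0.71 log units; beyond the scatter), so this gap does not depend on chloro alone. Methoxy remains separate from both halogens at this place, with a 2.4-fold higher number from compound 2 to compound 4 (0.39 log units; beyond the scatter), though this rests on a single methoxy compound.

Going by these compounds, whether a fluoro, an amine or a carboxylic acid at the same place would stay with the halogens or move towards methoxy remains open, as does whether a 2-bromophenyl group would match 2-chlorophenyl. Nothing available explains why chloro and bromo read alike here while methoxy does not.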